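The source may report more compounds than this note shows. Statements on the series, on what has been measured and on what is new or still open speak of the compounds shown alone.

Measured compounds in a functional assay on UACC-257 cells (Homo sapiens) for cytotoxicity, read by sulforhodamine B assay, with a stated time of 48 h; a higher number here means that more compound is tolerated, a lower number that less compound is tolerated:
compound 1 `ClCc1ccccc1Cn1cnc2c(Cl)nc(Cl)nc21` gives 8510 nM
compound 2 `ClCc1cccc(Cn2cnc3c(Cl)ncnc32)c1` gives 67600 nM

Of these two numbers in this assay, compound 1 stands lowest; compound 2 lies beyond the scatter above it. Compound 3 `Nc1nc(Cl)c2ncn(Cc3ccccc3CCl)c2n1` differs from compound 1 by amino in place of chloro on an aromatic carbon. For the measured compounds named here, no measured pair shows this change, so the step from compound 1 is expected to be modest, toward a higher number, near the edge of the scatter: a 1.8-fold higher number from compound 1 to compound 3 (0.25 log units; within the scatter). Compound 3 is estimated at 15000 nM, in a range from 4000 nM to 60000 nM.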

Compound 3, concentration lethal to 50% of the cells: > 100000 nM
Compound 3: only a limit was reported; the forecaster's own chance of this, stated with the estimate: 10%; middle value at least 6.6-fold (0.82 log units) away from the limit.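

In this assay, for the compounds shown here, amino in place of chloro on an aromatic carbon between two ring nitrogen atoms gives an at least 11-fold higher number from compound 1 to compound 3 (1.07 log units; beyond the scatter), the first step here that isolates a single place. Going by these compounds alone, no earlier pair could show that this position bears so strongly on the read-out. The value of compound 3 is a limit, not a number: the limit of > 100000 nM in this assay, at which 1 of the 3 values shown sits.

Going by these compounds, the true size of the step therefore stays open. So does whether a methoxy or a dimethylamino group on this carbon would act as amino does.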